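A few compounds are considered here, and "the series" means these few. Any claim that something is new, unique, unknown or untested is made for them only; others in the source may bear on it.

Compound 1 `CCCCCCCCC[C@@H](O)[C@H](C)N` gives 9200 nM in a functional assay on HeLa cells (Homo sapiens) for antiproliferative activity, read by sulforhodamine B assay, with a stated time of 48 h; a lower number here means a stronger inhibitor of growth, a higher number a weaker inhibitor of growth.
Compound 2 `CCCCCCCCC[C@@H](O)[C@@H](N)C(C)C` gives 20000 nM in this assay.

Within the data shown here, compound 2 stands highest of the two numbers in this assay, the only measured step being a 2.2-fold higher number from compound 1 to compound 2 (0.34 log units; beyond the scatter). Compound 3 `CCCCCCCCC[C@@H](O)[C@@H](N)[C@@H](C)O` carries the change (1-hydroxyethyl in place of isopropyl on a saturated chain carbon bound to an amine nitrogen and a saturated chain carbon). Among the measured compounds shown here, no measured step bears directly on the entering group; the one known step shows that branching at this carbon gave a modestly higher number from compound 1 to compound 2. The branching is kept in compound 3, so compound 3 is expected to stay near compound 2, with a step of a 1.3-fold lower number from compound 2 to compound 3 (0.12 log units; within the scatter). Compound 3 is therefore estimated at 15000 nM, between 6000 nM and 40000 nM.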

Compound 3, concentration for 50% growth inhibition: 17000 nM
The estimate for compound 3 lay 1.1-fold (0.05 log units) below the measured number, and the stated range covers the measured number.
By their numbers in this assay, from the lowest: compounds 1, 3 and 2 (each within the scatter of the next, the first and the last beyond it).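

In this assay, 1-hydroxyethyl and isopropyl on this carbon give numbers that cannot be told apart (a 1.2-fold lower number from compound 2 to compound 3 (0.07 log units; within the scatter)), so the hydrogen-bond donor and acceptor of the entering group bring no readable change. Against methyl, 1-hydroxyethyl also stays within the scatter (a 1.8-fold higher number from compound 1 to compound 3 (0.27 log units; within the scatter)), whereas isopropyl in that place lies beyond it. Nothing measured here explains these numbers.

The compounds shown leave open how an amine, a carboxylic acid or a longer chain would read on this carbon. From the compounds shown here alone, the opposite configuration at the defined stereocentre of 1-hydroxyethyl also stays open.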